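The source may hold more compounds than are shown below. What is called first, only, known or untested is meant among the compounds shown, and "the series" means these compounds.

Three compounds of this series have been run in an ADME assay on SK-OV-3 cells (Homo sapiens) for cytotoxicity, read by sulforhodamine B assay, with a stated time of 48 h, tested at 10 uM; on this read-out lower numbers stand for less inhibition and higher numbers for more inhibition at the one concentration tested (going by the name of the read-out). Compound 1 `COc1nc2ccc(Br)cc2cc1C(c1ccccc1)n1cc(-c2ccc(Br)cc2)nn1` gives 13.4%, the highest of the three numbers. Compound 2 `CCCCCCc1cn(C(c2ccccc2)c2cc3cc(Br)ccc3nc2OC)nn1` gives 7.17%, and compound 3 `COc1nc2ccc(Br)cc2cc1C(c1ccccc1)n1cc(CO)nn1` gives 3.23%. The step of a number 6.2 percentage points lower from compound 1 to compound 2 (within the scatter) stays within the scatter, whereas a number 10.2 percentage points lower from compound 1 to compound 3 (beyond the scatter) lies beyond it, though only modestly; the step of a number 3.9 percentage points lower from compound 2 to compound 3 (within the scatter) is again within the scatter.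

Compound 4 `COc1nc2ccc(Br)cc2cc1C(c1ccccc1)n1cc(-c2ccc(F)cc2)nn1` differs from compound 1 by fluoro in place of bromo on an aromatic carbon. The measured steps from compound 1 all replace the whole 4-bromophenyl group, not only the halogen on it, so none of them bears directly on this change; at most they show that even a full exchange of that group moves this assay by little. A step of this size, one halogen for another on the same aromatic carbon, is therefore expected to stay within the scatter, and compound 4 is estimated at 11%, between 2% and 22%, an expected step of a number 2.4 percentage points lower from compound 1 to compound 4 (within the scatter).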

Compound 4, a percentage reported as inhibition, at one concentration (the size of the read-out at that concentration, not a potency): 14.3%
The estimate for compound 4 lay 3.3 percentage points below the measured number, within the range that was stated.
By their numbers in this assay, from the lowest: compounds 3, 2, 1 and 4 (each within the scatter of the next, the first and the last beyond it).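

In this assay the only change shown that is limited to the halogen, fluoro in place of bromo on an aromatic carbon para to a large group, gives a number 0.9 percentage points higher from compound 1 to compound 4 (within the scatter) and so does not separate the two halogens. The 4-fluorophenyl group reads as the 4-bromophenyl group did: in place of hydroxymethyl it gives a number 11.1 percentage points higher from compound 3 to compound 4 (beyond the scatter) and the step stays modest, and in place of hexyl it gives a number 7.1 percentage points higher from compound 2 to compound 4 (within the scatter) and the step stays inside the usual spread. Nothing on hand offers an explanation for these numbers.

Open, on these data alone, is how a plain phenyl, or a methoxy group or an amine in place of the halogen, would read at this aromatic carbon. Also open, as far as these compounds go, is whether a carboxylic acid in place of the whole aryl group would fall near the hydroxymethyl compound.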